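A few compounds are considered here, and "the series" means these few. Any claim that something is new, unique, unknown or untested is made for them only; others in the source may bear on it.

Compound 1, `Cc1nc(N=C(N)N)nc2ccc(Cl)cc12`, and compound 2, `Cc1nc(N=C(N)N)nc2ccc(Br)cc12`, share one core and differ in a single place:
bromo in place of chloro on an aromatic carbon
In an assay on isolated protein for inhibition of Myeloperoxidase (Homo sapiens), with a stated time of 5 min (a higher number here means a weaker inhibitor, a lower number a stronger inhibitor), compound 1 gives 630 nM, and compound 2 gives 756 nM. That is a 1.2-fold higher number from compound 1 to compound 2 (0.08 log units; within the scatter), so the two numbers cannot be told apart with confidence.

Compound 3, `Cc1nc(N=C(N)N)nc2cc(Cl)ccc12`, is built from the same atoms as compound 1, joined differently; the difference between the two cores is not broken down here. In this assay compound 3 gives 96 nM, the lowest of the three numbers and the strongest inhibitor so far.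

Compound 4, `Cc1nc(N=C(N)N)nc2cc(Br)ccc12`, has not yet been measured. It differs from compound 3 as follows:
bromo in place of chloro on an aromatic carbon
This is the same change as from compound 1 to compound 2, bromo in place of chloro on an aromatic carbon at a place described in the same terms, and it occurs twice among these compounds. Because that earlier step was a 1.2-fold higher number from compound 1 to compound 2 (0.08 log units; within the scatter), compound 4 is expected to stay close to compound 3, with an estimated step of a 1.2-fold higher number from compound 3 to compound 4 (0.08 log units; within the scatter). Compound 4 is therefore estimated at 115 nM in this assay, most likely between 60 nM and 230 nM.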

Compound 4, half-maximal inhibitory concentration: 106 nM
Estimate against measurement, compound 4: 1.1-fold (0.04 log units) above; the range from low to high includes it.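

In this assay, bromo in place of chloro on the second core gives a 1.1-fold higher number from compound 3 to compound 4 (0.04 log units; within the scatter), so here too the two numbers cannot be told apart with confidence. Set beside the earlier step, the same change behaves alike on the two cores: the same change on two cores in this assay, a 1.2-fold higher number (0.08 log units; within the scatter) from compound 1 to compound 2 and a 1.1-fold higher number (0.04 log units; within the scatter) from compound 3 to compound 4, 1.1-fold (0.04 log units) apart, within the scatter of two such steps. Within the data shown here, this shows that, in these two pairs, swapping chloro for bromo leaves the number effectively unchanged on either core, but it rests on only two pairs and one assay, and it does not show that a change with a large effect would carry over in the same way, nor does it explain why the swap makes so little difference.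

From the compounds shown here alone, all four compounds carry either chloro or bromo, so it remains open how fluoro, a methoxy group, a nitrile or an amine would behave on these cores in this assay. Also open, going by these compounds, is whether a longer chain in place of the methyl group would shift the numbers, and whether the swap would still make so little difference on such a compound.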